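Fluoro removal on the aryl ring: compound 4 expected

The source may hold more compounds than are shown below. What is called first, only, known or untested is meant among the compounds shown, and "the series" means these compounds.

Measured compounds in an assay for inhibition of steroid 17-alpha-hydroxylase/17,20 lyase (Homo sapiens), using NADPH, tested at 0.2 uM; on this read-out lower numbers stand for a weaker effect and higher numbers for a stronger effect at the one concentration tested:
compound 1 `CCC(c1ccc(-c2cscc2C)cc1)n1ccnc1`, 27%
compound 2 `Fc1ccc(-c2csc(Cn3ccnc3)c2)cc1F`, 7%
compound 3 `CCC(c1ccc(-c2cscc2C)cc1F)n1ccnc1`, 41%

Compound 3 and compound 1 differ by hydrogen in place of fluoro on an aromatic carbon; the step is a number 14 percentage points lower from compound 3 to compound 1 (beyond the scatter). Compound 2 stands lowest of the three in this assay, with compound 1 nearest and compound 3 furthest. The difference between the core of compound 2 and the core of compound 3 is not broken down here.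

Compound 4 `Fc1ccc(-c2csc(Cn3ccnc3)c2)cc1` is not yet measured. It differs from compound 2 by hydrogen in place of fluoro on an aromatic carbon. This is the same kind of change as from compound 3 to compound 1, not the same: in compound 2 the place is ortho to a fluoro group and meta to a large group, whereas in compound 3 it is ortho to a group of 8 heavy atoms and meta to a 4-methylthiophen-3-yl group.

Going by the values given here, the expectation for compound 4 rests on the one step seen in this assay, a number 14 percentage points lower from compound 3 to compound 1 (beyond the scatter), and on compound 2 giving 7%, which leaves little room below. The expected step is a number 4 percentage points lower from compound 2 to compound 4 (within the scatter). Compound 4 is therefore estimated at 3%, between -5% and 12%.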

Compound 4, a percentage reported as inhibition, at one concentration (the size of the read-out at that concentration, not a potency): 0%
For compound 4 the middle estimate is 3 percentage points above the measured one; low and high end bracket the measured number.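

In this assay, hydrogen in place of fluoro on an aromatic carbon gives a number 7 percentage points lower from compound 2 to compound 4 (within the scatter). Set beside the earlier step, the change shows no measurable difference between the two cores: the same change on two cores in this assay, a number 14 percentage points lower (beyond the scatter) from compound 3 to compound 1 and a number 7 percentage points lower (within the scatter) from compound 2 to compound 4, 7 percentage points apart, within the scatter of two such steps This does not establish a step of one fixed size or a rule for the series, since only two pairs are available, the fluoro group does not sit in the same place in both, and the new step alone lies within the scatter, with compound 2 at 7% and compound 4 at 0% both low on this read-out.

On these data alone, only fluoro and hydrogen appear at these places, so the effect of a chloro group, a methoxy group or an amine there remains open. The gap between the core of compound 2 and the core of compound 3 also remains open, as no pair shown separates its parts.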